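The source may hold more compounds than are shown below. What is called first, only, known or untested is meant among the compounds shown, and "the series" means these compounds.

Compound 1 `Cn1cncc1C(O)(c1ccc(I)cc1)c1cc2cc([N+](=O)[O-])cc(-c3ccccc3)c2o1`: > 10000 nM (a limit)
Compound 2 `Cn1cncc1C(O)(c1ccc(C(=O)O)cc1)c1cc2cc([N+](=O)[O-])cc(-c3ccccc3)c2o1`: > 10000 nM (a limit)

In a functional assay on QG-56 cells (Homo sapiens) for antiproliferative activity (a lower number here means a stronger inhibitor, a higher number a weaker inhibitor), compound 2 stands at > 10000 nM, which is a limit of the assay and not a number. For the measured compounds named here, the series so far gives only (the limit of > 10000 nM in this assay, at which 2 of the 2 values shown sit). Compound 3 `Cn1cncc1C(O)(c1ccc(Br)cc1)c1cc2cc([N+](=O)[O-])cc(-c3ccccc3)c2o1` has not been measured. It swaps the 4-carboxyphenyl of compound 2 for 4-bromophenyl, bromo in place of carboxy on an aromatic carbon. Going by the values given here, the one measured step bearing on this change is a step that the two limits leave unreadable from compound 1 to compound 2, which touches the same place, and it gives no size and no direction. No clear move in this assay is therefore expected, and a number no higher from compound 2 to compound 3 (the limit leaves the size open) is the expected step. For compound 3 the estimate is 10000 nM, with an expected range of 3000 nM to 30000 nM, and another report as a limit is the likeliest outcome.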

Compound 3, half-maximal inhibitory concentration: 1480 nM
For compound 3 the middle estimate is 6.8-fold (0.83 log units) above the measured one; measured number below the stated range.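

In this assay, the aromatic carbon para to a large group now gives a readable result: bromo in place of carboxy gives an at least 6.7-fold lower number from compound 2 to compound 3 (0.82 log units; beyond the scatter), and bromo in place of iodo gives an at least 6.7-fold lower number from compound 1 to compound 3 (0.82 log units; beyond the scatter). The step between compound 1 and compound 2 cannot be read, so only compound 3 shows that this position responds to its substituent. A halogen here is not sufficient in itself: compound 1, which carries iodo, stays at > 10000 nM, a limit of the assay.

From the compounds shown here alone, whether the trend among halogens extends to chloro or fluoro, and how an amine or a methoxy group would behave here, stays open. The true size of both steps also stays open, with most of the series still at a limit: the limit of > 10000 nM in this assay, at which 2 of the 3 values shown sit.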